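This account rests on a few compounds, and the source may have more. Where it says the series, first, only, none or still open, it means among the compounds named here.

Two compounds with one shared core, each ending in a different aromatic group, have been measured. Compound 1 `COc1cc(/C=C/C(=O)/C=C/c2cccc3ccccc23)ccc1OCc1cn(CCCOc2cc(=O)oc3ccccc23)nn1` carries a naphthalen-1-yl end, and in a functional assay on COLO 205 cells (Homo sapiens) for inhibition, read by sulforhodamine B assay, with a stated time of 48 h, tested at 50 uM (on this read-out lower numbers stand for less inhibition of growth and higher numbers for more inhibition of growth at the one concentration tested), compound 1 gives 64%. Compound 2 `COc1cc(/C=C/C(=O)/C=C/c2ccccc2)ccc1OCc1cn(CCCCOc2cc(=O)oc3ccccc23)nn1` carries a phenyl end and a longer chain, and in this assay compound 2 gives 31%. Of these two numbers, that of compound 1 is the higher, and the gap is beyond the scatter. Compound 3 `COc1cc(/C=C/C(=O)/C=C/c2cccs2)ccc1OCc1cn(CCCOc2cc(=O)oc3ccccc23)nn1` has not yet been measured; it differs from compound 1 in one place: thiophen-2-yl in place of naphthalen-1-yl on a double-bonded chain carbon bound to a double-bonded chain carbon. The group that enters is smaller than the one that leaves. Among the measured compounds shown here, no measured pair shows this exact change, so the step from compound 1 to compound 3 in this assay is expected to be a moderate drop beyond the scatter, a number 22 percentage points lower from compound 1 to compound 3 (beyond the scatter). In this assay compound 3 is estimated at 42%, with a likely range from 22% to 62%.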

Compound 3, percent growth inhibition at one concentration: 55%
Compound 3: the middle estimate sits 13 percentage points below what was measured, within the range that was stated.
By their numbers in this assay, from the lowest: compound 2; then compounds 3 and 1 (each within the scatter of the next).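

Among the compounds shown here, replacing naphthalen-1-yl with thiophen-2-yl in this assay gives a number 9 percentage points lower from compound 1 to compound 3 (within the scatter) and is the first change here that can be read at a single place, since compound 1 and compound 2 differ in both end group and chain. At this place on the double-bonded chain carbon, one five-membered aromatic ring with sulfur can therefore stand in for two six-membered rings of carbon without a step beyond the scatter, at the one concentration tested. Nothing here explains why the step is this small.

From the compounds shown here alone, compound 2 changes two things at once, so the separate contributions of its phenyl end and its longer chain stay open. Going by these compounds, how an end such as pyridin-3-yl, or a phenyl ring carrying a carboxylic acid, would fare at this place also remains unknown.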